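The source may hold more compounds than are shown below. What is called first, only, known or untested is meant among the compounds shown, and "the series" means these compounds.

Compound 1 `CC1=C(SCCCCO)C(=O)c2ccccc2C1=O` and compound 2 `CC1=C(SC(C)C(C)O)C(=O)c2ccccc2C1=O` share one core and differ only in the chain carried on the sulfur. In a functional assay on HepG2 cells (Homo sapiens) for inhibition (on this read-out lower numbers stand for stronger inhibition and higher numbers for weaker inhibition), compound 1 gives > 10000 nM, which is a limit of the assay and not a number. In this assay compound 2 gives > 10000 nM, again a limit rather than a number. The step that the two limits leave unreadable from compound 1 to compound 2 cannot be read because of the limit of > 10000 nM in this assay, at which 2 of the 2 values shown sit. Compound 2 thus stands only at the limit, with no finer placement possible. Compound 3 `CC1=C(SCC(C)O)C(=O)c2ccccc2C1=O` departs from compound 2 by hydrogen in place of methyl on a saturated chain carbon bound to a saturated chain carbon and a sulfur. Among the measured compounds shown here, the single measured step, the exchange of chains between the first two compounds, left both values at the limit, so it gives no direction, and a step within the scatter is the plainest expectation. Compound 3 is therefore expected near 20000 nM, within 5000 nM to 80000 nM, most likely reported again only as a limit. The expected step is a step that the limit leaves unreadable from compound 2 to compound 3.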

Compound 3, half-maximal inhibitory concentration: 5590 nM
Beside the measured number, compound 3's estimate is 3.6-fold (0.55 log units) above it; the range from low to high includes it.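

In this assay, among the compounds shown here, compound 3 is the only one of the three compounds with a number rather than a limit, so the loss of the methyl on a saturated chain carbon bound to a saturated chain carbon and a sulfur gives this position its first readable value. Read against the earlier limits, the change from 2-hydroxy-1-methylpropyl to 2-hydroxypropyl is an at least 1.7-fold lower number from compound 2 to compound 3 (0.25 log units; that floor lies within the scatter), and the exchange of 3-hydroxypropyl for 1-hydroxyethyl on a saturated chain carbon bound to a sulfur is an at least 1.7-fold lower number from compound 1 to compound 3 (0.25 log units; that floor lies within the scatter). Both steps are floors, and their true size stays unknown because each starts from a limit: the limit of > 10000 nM in this assay, at which 2 of the 3 values shown sit.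

On these data alone, how far either step reaches past its floor remains open. Also open, as far as these compounds go, is how the number would move with an amine or a carboxylic acid in place of the hydroxyl on this chain.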